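A few compounds are considered here, and "the series" means these few. Any claim that something is new, unique, unknown or untested is made for them only; others in the source may bear on it.

Measured so far:
compound 1 `CC(=O)OC/C(=C\C1CCCCC1)C(=O)c1ccccc1` — 21000 nM
compound 2 `CC(=O)OC/C(=C\C1CCCCC1)C(=O)c1ccc(Cl)cc1` — 24000 nM

Both compounds were run in a functional assay on HeLa cells (Homo sapiens) for inhibition, read by sulforhodamine B assay, with a stated time of 48 h; on this read-out higher numbers stand for weaker inhibition of growth and lower numbers for stronger inhibition of growth. Among the measured compounds shown here, compound 1 gives 21000 nM and compound 2 gives 24000 nM, so compound 2 holds the higher of the two numbers, though the one step that links them, a 1.1-fold higher number from compound 1 to compound 2 (0.06 log units; within the scatter), lies within the scatter, and the two compounds cannot be ordered on this read-out.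

Compound 3 `CC(=O)OC/C(=C\c1ccc(Cl)cc1Cl)C(=O)c1ccc(Cl)cc1` is not yet measured in this assay. It differs from compound 2 in one place: 2,4-dichlorophenyl in place of cyclohexyl on a double-bonded chain carbon bound to a double-bonded chain carbon. For the measured compounds named here, no measured step bears directly on this change; the only step in hand, a 1.1-fold higher number from compound 1 to compound 2 (0.06 log units; within the scatter), concerns a chloro substituent on the aromatic ring bound to the carbonyl, not the group on the double-bonded chain carbon, and it was within the scatter. The expectation for compound 3 therefore rests on the shared core alone and carries a wide range. A moderately lower number is estimated, and the step of a 1.7-fold lower number from compound 2 to compound 3 (0.23 log units; within the scatter) is expected, with the range wide enough to include no change beyond the scatter. For compound 3 the estimate is 14000 nM, between 4000 nM and 45000 nM.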

Compound 3, concentration for 50% growth inhibition: 4600 nM
The estimate for compound 3 lay 3.0-fold (0.48 log units) above the measured number; the range from low to high includes it.
By their numbers in this assay, from the lowest: compound 3; then compounds 1 and 2 (each within the scatter of the next).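

In this assay, the place on a double-bonded chain carbon bound to a double-bonded chain carbon responds to substitution: 2,4-dichlorophenyl in place of cyclohexyl gives a 5.2-fold lower number from compound 2 to compound 3 (0.72 log units; beyond the scatter). Among the compounds shown here, this is the only step that lies beyond the scatter, whereas chloro in place of hydrogen on an aromatic carbon gave a 1.1-fold higher number from compound 1 to compound 2 (0.06 log units; within the scatter). The exchange replaces a six-membered non-aromatic ring of carbon only with a six-membered aromatic ring bearing two chlorines, with no hydrogen-bond donors or acceptors and no net charge on either group, and no measurement in hand accounts for the step.

The compounds shown leave open whether the step follows the aromatic ring itself or its two chlorine atoms, a question that a plain phenyl group at this place would address. Also open, on these data alone, is how the number would respond at other parts of the shared core, for instance with a hydroxyl group or an amine in place of the acetyloxy group.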